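Chloro added to compound 1: expected step

The compounds below may be only part of what the source reports. "The series", "measured", "known", "first", "only" and "open" are said of these compounds alone.

For the measured compounds named here, in a functional assay on HUVEC cells (Homo sapiens) for inhibition, with a stated time of 4 days (a higher number here means a weaker inhibitor, a lower number a stronger inhibitor), compound 1 `COc1ccc(C(N)=O)cc1/C=C/c1ccccc1F` gives 2000 nM and stands lowest of the two numbers so far, with compound 2 `COc1ccc(C(N)=O)cc1/C=C/c1ccccc1OC(F)(F)F` at 8900 nM as its only neighbour. Compound 3 `COc1ccc(C(N)=O)cc1/C=C/c1ccc(Cl)cc1F` keeps the core of compound 1 and differs by one change (chloro in place of hydrogen on an aromatic carbon): chloro in place of hydrogen on an aromatic carbon, meta to a fluoro group and para to a large group. Going by the values given here, only one measured step bears on this, and only indirectly: the number rises (a 4.5-fold higher number from compound 1 to compound 2 (0.65 log units; beyond the scatter)) when trifluoromethoxy replaces fluoro. Among the compounds with values here, that is a different exchange at a different place, and no chloro compound has been measured yet. A small step is therefore expected, leaning upward and perhaps not beyond the scatter (a 1.4-fold higher number from compound 1 to compound 3 (0.15 log units; within the scatter)). The expected value for compound 3 is 2800 nM (estimated range 900 nM to 8000 nM).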

Compound 3, half-maximal inhibitory concentration: 1700 nM
Estimate against measurement, compound 3: 1.6-fold (0.22 log units) above, and the stated range covers the measured number.
By their numbers in this assay, from the lowest: compounds 3 and 1 (each within the scatter of the next); then compound 2.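

In this assay, for the compounds shown here, chloro in place of hydrogen on an aromatic carbon, meta to a fluoro group and para to a large group, gives a 1.2-fold lower number from compound 1 to compound 3 (0.07 log units; within the scatter), so this position accepts a chlorine with no step that stands out from repeat measurements. Going by these compounds alone, the only earlier step came from exchanging the fluoro group itself, with a 4.5-fold higher number from compound 1 to compound 2 (0.65 log units; beyond the scatter); this is the first reading from a second place on the ring that carries the fluoro group, and the number there stays level with compound 1. Nothing measured on these compounds gives a reason for the level step.

A single substituent shows no trend at this position, so a methoxy group, an amine or a carboxylic acid there could read quite differently. Also open, from the compounds shown here alone, is whether chloro stays level when trifluoromethoxy stands in place of fluoro.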